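This account rests on a few compounds, and the source may have more. Where it says the series, first, only, none or still open, it means among the compounds named here.

Working notes on the series. In an assay on cells (Hepatocyte) for inhibition of glucokinase regulatory protein (Mus musculus), with stated times of 20 min and 40 min (a higher number here means that more compound is needed for the effect, a lower number that less compound is needed), compound 1 `CC#C[C@H]1CN(S(=O)(=O)c2ccc(N)nc2)CCN1c1ccc(S(=O)(=O)NCC2CC2)cc1` gives 271 nM. Compound 2 `CC#C[C@H]1CN(S(=O)(=O)c2ccc(N)nc2)CCN1c1ccc(C(C)=O)cc1` reaches only the limit of this assay, > 12500 nM, not a measured number; the step of an at least 46-fold higher number from compound 1 to compound 2 (1.66 log units; beyond the scatter) thus has a lower bound set by the limit of > 12500 nM in this assay, at which 1 of the 2 values shown sits. Compound 3 `CC#C[C@H]1CN(S(=O)(=O)c2ccc(N)nc2)CCN1c1ccc(C(=O)NC)cc1` follows from compound 2 by methylamino in place of methyl on a carbonyl carbon. Among the measured compounds shown here, only the step from compound 1 to compound 2 bears on this change, and it ran the other way; a methylcarbamoyl is nearer to compound 1 in kind than an acetyl, so a lower number than the limit is expected, though compound 3 may also stay at the limit. Compound 3 is estimated in this assay at 4000 nM, with a range from 800 nM to 12500 nM, an expected step of an at least 3.1-fold lower number from compound 2 to compound 3 (0.49 log units; beyond the scatter).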

Compound 3, half-maximal effective concentration: 4050 nM
The estimate for compound 3 lay 1.0-fold (0.01 log units) below the measured number; low and high end bracket the measured number.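

In this assay, methylamino in place of methyl on the carbonyl carbon gives a measurable number, an at least 3.0-fold lower number from compound 2 to compound 3 (0.48 log units; beyond the scatter). Compound 2 stands at a limit, not a number, so the size of that step is only a lower bound: the limit of > 12500 nM in this assay, at which 1 of the 3 values shown sits. The methylcarbamoyl still falls well short of the (cyclopropylmethyl)sulfamoyl, a 15-fold higher number from compound 1 to compound 3 (1.17 log units; beyond the scatter).

From the compounds shown here alone, whether that remaining gap belongs to the carbonyl in place of the sulfonyl or to the loss of the cyclopropylmethyl stays open. A methylsulfamoyl or a cyclopropylmethyl amide on the same aromatic carbon would separate the two.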